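This account rests on a few compounds, and the source may have more. Where it says the series, first, only, none or still open, it means among the compounds named here.

Measured so far:
- Compound 1 `COc1ccc(/C=C/C(=O)Nc2nnc(-c3ccccc3)[nH]2)cc1OC`: 1210000 nM
- Compound 2 `O=C(/C=C/c1ccc(O)cc1)Nc1nnc(-c2ccccc2)[nH]1`: 1850000 nM

Both compounds share the same core and were tested in an ADME assay on Vero cells (Chlorocebus sabaeus) for cytotoxicity, read by MTT assay, with a stated time of 72 h; a higher number here means that more compound is tolerated, a lower number that less compound is tolerated. Compound 1 gives 1210000 nM, and compound 2 gives 1850000 nM. These two numbers sit within the scatter of each other, so neither compound can be said to be tolerated better or worse than the other on this evidence.

Compound 3 `Cc1ccc(/C=C/C(=O)Nc2nnc(-c3ccccc3)[nH]2)cc1` has not been measured in this assay. It differs from compound 2 in one place: methyl in place of hydroxy on an aromatic carbon. Both measured compounds already sit at very high concentrations, and nothing measured here shows that a change on this ring moves the number beyond the scatter. The step from compound 2 to compound 3 is therefore expected to be small, a 1.2-fold lower number from compound 2 to compound 3 (0.09 log units; within the scatter), with no clear direction. Compound 3 is expected to give about 1500000 nM, estimated between 600000 nM and 4000000 nM.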

Compound 3, half-maximal cytotoxic concentration: 1760000 nM
Beside the measured number, compound 3's estimate is 1.2-fold (0.07 log units) below it, within the range that was stated.
By their numbers in this assay, from the lowest: compounds 1, 3 and 2 (each within the scatter of the next).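

In this assay, among the compounds shown here, putting methyl in place of hydroxy on the aromatic carbon para to a large group gives a 1.1-fold lower number from compound 2 to compound 3 (0.02 log units; within the scatter), so this pair offers the first direct look at a single change at this position, and the two numbers cannot be told apart. Hydroxy counts one hydrogen-bond donor and one acceptor while methyl counts neither, yet in this pair that difference leaves no readable mark on the result. No measurement bearing on the reason for this outcome is available.

Still open, from the compounds shown here alone, is whether a different kind of group at this position, such as an amine or a carboxylic acid, would give a number beyond the scatter. A longer chain here is equally untested by these compounds, and this single pair says nothing about changes elsewhere on the shared core.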